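Imidazole to methylpiperazine on the butyl-linked series

The compounds below may be only part of what the source reports. "The series", "measured", "known", "first", "only" and "open" are said of these compounds alone.

Measured in a functional assay on MDA-MB-231 cells (Homo sapiens) for cytotoxicity, read by MTT assay, with a stated time of 72 h; a lower number here means a stronger inhibitor, a higher number a weaker inhibitor:
- compound 1 `O=C1c2c[n+]([O-])c3ccccc3c2C(=O)c2c1c1ccccc1n2CCCCn1ccnc1` gives 210 nM
- compound 2 `CC1(C)OCC(Cn2cc(Cn3c4c(c5ccccc53)C(=O)c3c[n+]([O-])c5ccccc5c3C4=O)nn2)O1` gives 230 nM

Compound 1 holds the lower of the two numbers, but the gap to compound 2 lies within the scatter, so the pair does not rank. Compound 3 `CN1CCN(CCCCn2c3c(c4ccccc42)C(=O)c2c[n+]([O-])c4ccccc4c2C3=O)CC1`, still unmeasured, keeps the shared core and carries 4-methylpiperazin-1-yl in place of 1H-imidazol-1-yl on a saturated chain carbon, four bonds along the chain from an aromatic nitrogen. For the measured compounds named here, no measured pair isolates this change. Going by the values given here, the only guide is that compound 2 , with a different side chain, still reads 230 nM. In this assay a small move towards a higher number is therefore expected, possibly none beyond the scatter. The expected 1.4-fold higher number from compound 1 to compound 3 (0.15 log units; within the scatter) is only an estimate. For compound 3 the estimated value is 300 nM, with an expected range of 120 nM to 750 nM.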

Compound 3, half-maximal inhibitory concentration: 110 nM
Compound 3: middle estimate off by 2.7-fold (0.44 log units), on the high side; the measured number lies below the stated range.
By their numbers in this assay, from the lowest: compounds 3, 1 and 2 (each within the scatter of the next, the first and the last beyond it).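

In this assay, the change on a saturated chain carbon, four bonds along the chain from an aromatic nitrogen, reads as a 1.9-fold lower number from compound 1 to compound 3 (0.28 log units; within the scatter), so the two compounds do not rank. This position therefore carries either one five-membered aromatic ring or one six-membered non-aromatic ring with the larger group, 4-methylpiperazin-1-yl, and the step stays within the scatter. No measurement at hand bears on why the change reads this way.

Still open, from the compounds shown here alone, is whether other groups at the chain end, such as morpholine or a dimethylamino group, also stay within the scatter of compound 1. Also open, going by these compounds, is how a shorter propyl chain or a longer hexyl chain bearing 4-methylpiperazin-1-yl would read, since this single pair covers only the butyl chain.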